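The compounds below may be only part of what the source reports. "The series", "measured", "known", "first", "only" and "open" are said of these compounds alone.

Among the measured compounds shown here, compound 2 `COc1cc(Cl)cc(-c2nn(-c3cccc(NC(=O)Nc4cccc(C(F)(F)F)c4)c3)cc2-c2ccncc2)c1` stands highest of the two numbers so far in a functional assay on CAKI-1 cells (Homo sapiens) for inhibition, read by sulforhodamine B assay, with a stated time of 48 h, tested at 100 uM; on this read-out higher numbers stand for a weaker effect at the one concentration tested and lower numbers for a stronger effect: compound 2 gives -20%, while compound 1 `COc1cc(Cl)cc(-c2nn(-c3cccc(NC(=O)Nc4ccc(Cl)c(C(F)(F)F)c4)c3)cc2-c2ccncc2)c1` gives -40%. For the measured compounds named here, the one measured step, a number 20 percentage points higher from compound 1 to compound 2 (beyond the scatter), concerns a substituent on the outer aromatic ring and nothing else. Compound 3 `COc1cc(Cl)cc(-c2nn(-c3cccc(NC(=O)c4cccc(C(F)(F)F)c4)c3)cc2-c2ccncc2)c1` differs from compound 2 by 3-(trifluoromethyl)phenyl in place of (3-(trifluoromethyl)phenyl)amino on a carbonyl carbon. Going by the values given here, no measured step alters the carbonyl or its neighbours, so the move from compound 2 to compound 3 has no precedent in this set; the step from compound 1 to compound 2, though beyond the scatter, is a different kind of change and cannot be carried over. For compound 3 no step beyond the scatter is therefore expected in this assay, the expected change being a number 5 percentage points higher from compound 2 to compound 3 (within the scatter), with a wide margin either way. The estimate for compound 3 is -15%, within a range from -45% to 15%.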

Compound 3, a percentage reported as activity, at one concentration (the size of the read-out at that concentration, not a potency): 21%
Estimate against measurement, compound 3: 36 percentage points below; the whole stated range lies below it.
By their numbers in this assay, from the lowest: compound 1; then compound 2; then compound 3.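

In this assay, 3-(trifluoromethyl)phenyl in place of (3-(trifluoromethyl)phenyl)amino on a carbonyl carbon gives a number 41 percentage points higher from compound 2 to compound 3 (beyond the scatter), a large step where the chloro step on the outer ring was modest, so the link on the carbonyl carbon matters to this read-out at the tested concentration. The same position, with the (4-chloro-3-(trifluoromethyl)phenyl)amino group leaving, gives a number 61 percentage points higher from compound 1 to compound 3 (beyond the scatter), and compound 3 at 21% is the only one of the three with a positive number and has the weakest effect. Nothing on hand accounts for the size of these steps.

Open, on these data alone, is whether a methylene group or an oxygen atom in place of the amino nitrogen would stay with compound 2 or move towards compound 3. Also open, as far as these compounds go, is whether a chloro group on the outer ring of compound 3 would shift the number at all.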